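Chain extension in compound 1 toward compound 4

The source may report more compounds than this note shows. Statements on the series, on what has been measured and on what is new or still open speak of the compounds shown alone.

The measured compounds and their values:
compound 1, `N=c1oc2ccc(Br)cc2cc1C(=O)NCCO`: 15%
compound 2, `COc1cccc2cc(C(=O)Nc3c(C#N)ncn3-c3ccccc3)c(=N)oc12`: 9%
compound 3, `COc1cccc2cc(C(=O)NC3CCCC3)c(=N)oc12`: 47%

All three were tested in an assay on HEK293 cells for displacement of a labelled ligand from adenosine receptor A2b (Homo sapiens), read by scintillation counting, with a stated time of 30 min, tested at 10 uM; on this read-out lower numbers stand for less inhibition and higher numbers for more inhibition at the one concentration tested (going by the name of the read-out). In this assay compound 1 gives 15%, which is the second highest of the three numbers. Its nearest neighbour is compound 2, whose reading of 9% lies within the usual scatter of compound 1, so no order between these two can be claimed. Furthest away is compound 3, whose reading of 47% stands beyond the scatter above compound 1.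

The account now turns to compound 4, `N=c1oc2ccc(Br)cc2cc1C(=O)NCCCO`, which has not yet been measured. Compared with compound 1 the difference is hydroxymethyl in place of hydroxy on a saturated chain carbon, two bonds along the chain from an amide-type nitrogen. The hydroxymethyl replaces the hydroxy on a saturated chain carbon, two bonds along the chain from an amide-type nitrogen; the rest of the molecule, including the shared core, is unchanged.

Within the data shown here, no step between two measured compounds differing in one place is available, so the size of this change cannot be read from a measured pair. A chain extension by one carbon at the hydroxy end of the amide substituent is expected to give no step beyond the scatter in this assay. The step expected from compound 1 to compound 4 is therefore a number 2 percentage points higher from compound 1 to compound 4 (within the scatter). Compound 4 is estimated to give 17%, with a range from 5% to 35%.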

Compound 4, a percentage reported as inhibition, at one concentration (the size of the read-out at that concentration, not a potency): 25%
Estimate against measurement, compound 4: 8 percentage points below, and the stated range covers the measured number.
By their numbers in this assay, from the lowest: compounds 2, 1 and 4 (each within the scatter of the next, the first and the last beyond it); then compound 3.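

In this assay, among these compounds, the change to hydroxymethyl in place of hydroxy on a saturated chain carbon, two bonds along the chain from an amide-type nitrogen, gives a number 10 percentage points higher from compound 1 to compound 4 (within the scatter) and so provides the first step measured between compounds that differ in one place. The earlier compounds shown here offered no such pair and could say nothing about this chain, whereas this pair shows that going from 2-hydroxyethyl to 3-hydroxypropyl on the amide-type nitrogen, with the shared core unchanged, does not move the reading beyond the usual scatter of this kind of measurement. Nothing measured here gives a reason for the size of this step.

A single step cannot show whether the chain has any real effect on the reading, nor whether a longer chain ending in hydroxy would continue to stay within the scatter of compound 1. The compounds shown also leave open what happens at this chain end when an amine or a carboxylic acid stands in place of the hydroxy.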